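This account rests on a few compounds, and the source may have more. Where it says the series, first, only, none or still open, it means among the compounds named here.

Measured so far:
- compound 1 `CC/N=C(\S)NCCCCCn1nc(-c2ccccc2)ccc1=O`: 66.4%
- compound 2 `O=c1ccc(-c2ccccc2)nn1CCCCNC(=S)NCc1ccccc1`: 5.4%
- compound 3 `O=c1ccc(-c2ccccc2)nn1CCCCNC(=S)Nc1ccccc1`: 38.4%

All three were tested in a functional assay on the whole organism with Rattus norvegicus as the target, at a dose of 100 mg/kg; on this read-out lower numbers stand for less inhibition and higher numbers for more inhibition at the one dose given (going by the name of the read-out). On these numbers compound 3 stands in the middle: compound 1 gives a higher number, compound 2 a lower one, and both gaps lie beyond the usual scatter. Among the compounds with values here, the only single-point change among the measured compounds is the one from compound 2 to compound 3, where phenyl replaces benzyl on an amide-type nitrogen; it gives a number 33 percentage points higher from compound 2 to compound 3 (beyond the scatter), a large step upward.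

Compound 4 `C/N=C(\NC#N)NCCCCn1nc(-c2ccccc2)ccc1=O` is not yet measured. It differs from compound 3 at an amine nitrogen whose other neighbours are a saturated chain carbon: a group of 6 heavy atoms (3 carbon, 3 nitrogen; no ring) in place of a group of 9 heavy atoms (7 carbon, 1 nitrogen, 1 sulfur; one six-membered aromatic ring of carbon only), on an amine nitrogen. Within the data shown here, no measured step covers this kind of change; the step from compound 2 to compound 3 concerns a different part of the same group and says only that this position can move the read-out strongly in either direction. The whole thiourea end of compound 3 is exchanged here, so a change beyond the scatter is plausible but its direction cannot be read from the shown steps.

Compound 4 is therefore expected to give about 35%, within a range from 5% to 65%. This estimate amounts to an expected step of a number 3.4 percentage points lower from compound 3 to compound 4 (within the scatter), which is meant as a cautious middle rather than a firm prediction.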

Compound 4, a percentage reported as inhibition, in the whole organism at one dose (the size of the read-out at that dose, not a potency): 79%
Estimate against measurement, compound 4: 44 percentage points below, and the stated range ends below it.
By their numbers in this assay, from the lowest: compound 2; then compound 3; then compound 1; then compound 4.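

In this assay, an end group with no ring can take the number well past that of the aromatic thiourea end: a group of 6 heavy atoms (3 carbon, 3 nitrogen; no ring) in place of a group of 9 heavy atoms (7 carbon, 1 nitrogen, 1 sulfur; one six-membered aromatic ring of carbon only) gives a number 40.6 percentage points higher from compound 3 to compound 4 (beyond the scatter). The earlier step only swapped benzyl for phenyl, whereas this one shows that neither the sulfur nor the aromatic ring is needed for a high number on this amine nitrogen. The ring-free end of compound 1 already gave a high number, and the smaller change on a saturated chain carbon, four bonds along the chain from an aromatic nitrogen, gives a number 12.6 percentage points higher from compound 1 to compound 4 (beyond the scatter).

Nothing measured here accounts for either rise.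
Since the sulfur, the ring and the rest of the end group all change at once, the compounds shown leave open which part matters, and whether a urea end, with oxygen in place of the sulfur, or a longer chain carrying the end group of compound 4 would keep the number this high.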